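The compounds below may be only part of what the source reports. "The series", "measured", "known", "first", "only" and "open" are said of these compounds alone.

Series notes. Compound 1 `O=C(CCCCC1CCSS1)NCc1cn(CCCOc2ccc3ccc(=O)oc3c2)nn1` and compound 2 `O=C(CCCCC1CCSS1)NCc1cn(CCCOc2ccc3cc(-c4ccccc4)c(=O)oc3c2)nn1` share one core. In a functional assay on PC-12 cells (Rattus norvegicus) for cytotoxicity, read by MTT assay, with stated times of 3 h and 2 h, tested at 1 uM (a higher number here means a stronger effect of the compound at the concentration tested, a lower number a weaker effect), compound 1 gives 37.2% and compound 2 gives 31.9%. The step of a number 5.3 percentage points lower from compound 1 to compound 2 (within the scatter) comes from the change (phenyl in place of hydrogen on an aromatic carbon). Compound 3 `O=C(CCCCC1CCSS1)NCc1cn(CCCCOc2ccc3ccc(=O)oc3c2)nn1` carries a different core; the difference between the cores of compound 1 and compound 3 is not broken down here. In this assay, among the compounds with values here, compound 3 gives 45.9%, which sits within the scatter of compound 1 and beyond the scatter from compound 2; with only three numbers no pattern is claimed. Compound 4 `O=C(CCCCC1CCSS1)NCc1cn(CCCCOc2ccc3cc(-c4ccccc4)c(=O)oc3c2)nn1` has not been measured. It differs from compound 3 by phenyl in place of hydrogen on an aromatic carbon, the same change, at the same place, as from compound 1 to compound 2; it occurs twice in all among these compounds. The earlier step of a number 5.3 percentage points lower from compound 1 to compound 2 (within the scatter) lay within the scatter. On that basis a step of similar size is expected for compound 4, a number 5.9 percentage points lower from compound 3 to compound 4 (within the scatter). In this assay compound 4 is thus estimated at 40%. For compound 4 the expected range runs from 30% to 50%.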

Compound 4, a percentage reported as activity, at one concentration (the size of the read-out at that concentration, not a potency): 34.8%
The estimate for compound 4 lay 5.2 percentage points above the measured number; the range from low to high includes it.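

Phenyl in place of hydrogen on an aromatic carbon gives, in this assay, a number 11.1 percentage points lower from compound 3 to compound 4 (beyond the scatter). Set beside the earlier step on the core of compound 1, the step on the core of compound 3 cannot be told apart from it, so within this pair of cores the change carries over without a measurable difference in size: the same change on two cores in this assay, a number 5.3 percentage points lower (within the scatter) from compound 1 to compound 2 and a number 11.1 percentage points lower (beyond the scatter) from compound 3 to compound 4, 5.8 percentage points apart, within the scatter of two such steps. Within the data shown here, this does not establish a rule for the series: there are only two steps, just one of them lies beyond the scatter, and neither says why the number moves or how the change would behave on any further core.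

The compounds shown leave open how other groups on the same aromatic carbon, such as a methyl, an amine or a carboxylic acid, would read in this assay. Also open, as far as these compounds go, is whether the change would carry over in the same way on a core with a longer chain than those of compound 3 and compound 1.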